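Series notes: methoxymethoxy in place of fluoro on compound 3

This account rests on a few compounds, and the source may have more. Where it says the series, first, only, none or still open, it means among the compounds named here.

In a toxicity assay on THP-1 cells (Homo sapiens) for cytotoxicity, read by MTT assay, with a stated time of 72 h (on this read-out higher numbers stand for an effect only at larger amounts of compound and lower numbers for an effect already at smaller amounts), compound 1 `Cn1c(/C=N/N=C(/N)S)cc2ccccc21` gives only the limit > 200000 nM. Compound 2 `CCCCn1cc(/C=N/NC(N)=S)c2cccc(C)c21` likewise gives only the limit > 200000 nM in this assay. Compound 3 `NC(=S)N/N=C/c1ccc(F)c2ccccc12` gives 39000 nM in this assay; this is the only number shown, the remaining values being (the limit of > 200000 nM in this assay, at which 2 of the 3 values shown sit). Compound 4 `COCOc1ccc(/C=N/NC(N)=S)c2ccccc12` carries methoxymethoxy in place of fluoro on an aromatic carbon, methoxymethoxy in place of fluoro on an aromatic carbon. Within the data shown here, no measured step between two compounds is available, so the size of such a change cannot be read from the series itself. Compound 4 is therefore expected to stay close to compound 3, with an expected step of a 1.0-fold higher number from compound 3 to compound 4 (0.01 log units; within the scatter) and no direction beyond the scatter. The estimate for compound 4 in this assay is 40000 nM, expected between 15000 nM and 120000 nM.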

Compound 4, half-maximal effective concentration: > 200000 nM
Compound 4: a limit, no number; the forecaster's own chance of this, stated with the estimate: 25%; middle value at least 5.0-fold (0.69 log units) away from the limit.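

In this assay, among these compounds, methoxymethoxy in place of fluoro on this aromatic carbon gives an at least 5.1-fold higher number from compound 3 to compound 4 (0.70 log units; beyond the scatter), the only measured step, so this position does respond to a change of group. The reading for compound 4 is a limit and not a number. Compound 3 remains the only compound with a number: the limit of > 200000 nM in this assay, at which 3 of the 4 values shown sit.

Open, on these data alone, is whether compound 3, at 39000 nM, would keep a number of that order with a methoxy or a hydroxyl in place of fluoro. The same question stands for an amine at this place.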